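Swapping dimethylamino for pyrrolidin-1-yl

This account rests on a few compounds, and the source may have more. Where it says the series, first, only, none or still open, it means among the compounds named here.

Part of any compound in the blood sits on plasma protein, and the rest stays free. In an ADME assay on a cell-free system (plasma, Homo sapiens) for protein binding, compound 1 `CNc1nccc(N2CC[C@H](NC(=O)Nc3ccc(CN(C)C)c(C(F)(F)F)c3)C2)n1` gives 94.3% as its reading, while compound 2 `CNc1nccc(N2CC[C@H](NC(=O)Nc3ccc(OC(F)(F)F)cc3)C2)n1` gives 97.7% as its reading. Of these two, compound 1 leaves the larger share free, and the gap between them lies beyond the scatter of repeated measurements. The two compounds differ in more than one place, so no measured single change is available as a guide.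

Compound 3 `CNc1nccc(N2CC[C@H](NC(=O)Nc3ccc(CN4CCCC4)c(C(F)(F)F)c3)C2)n1` keeps the core of compound 1 and alters one group: pyrrolidin-1-yl in place of dimethylamino on a saturated chain carbon bound to an aromatic carbon. With nothing measured for this swap, the expectation starts from compound 1 at 94.3% as its reading and allows only a small move towards more binding. The estimated a 1.3-fold lower unbound fraction from compound 1 to compound 3 (0.10 log units; within the scatter) is expected to stay within the scatter. For compound 3 the expected reading in this assay is 95.5% as the middle estimate, with a range from 91% to 97.5% around it.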

Compound 3, plasma protein binding: 86.5%
Estimate against measurement, compound 3: 3.0-fold (0.48 log units) (unbound fraction) below, outside the stated range (below it).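

This single pair shows that the group on a saturated chain carbon bound to an aromatic carbon is not a silent spot: in this assay, pyrrolidin-1-yl in place of dimethylamino gives a 2.4-fold higher unbound fraction from compound 1 to compound 3 (0.37 log units; beyond the scatter). The entering group has more heavy atoms and adds a five-membered non-aromatic ring, while the hydrogen-bond donor and acceptor counts stay unchanged, so in this pair the larger group goes with more free compound rather than less. Nothing measured here explains why the free share moves this way.

For the compounds shown here, with only this one step, the effect of the ring cannot be separated from the effect of the extra carbon atoms, since both arrive together in pyrrolidin-1-yl. Diethylamino, an open-chain group, and piperidin-1-yl or morpholin-4-yl, both six-membered rings, would help to tell these apart at the same place, and it remains open whether the swap would shift plasma protein binding in the same direction on a different core.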